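A few compounds are considered here, and "the series" means these few. Any claim that something is new, unique, unknown or untested is made for them only; others in the source may bear on it.

Measured compounds:
compound 1 `CCCc1nc(CC)c(C(=O)OCCCN2C(=O)c3ccccc3C2=O)n1Cc1ccc(-c2ccccc2S(=O)(=O)NC(=O)OCCC(C)C)cc1F`, 3 nM in an assay on isolated protein for binding affinity to Type-2 angiotensin II receptor (Homo sapiens); on this read-out lower numbers stand for stronger inhibition and higher numbers for weaker inhibition
compound 2 `CCCCN(Cc1ccccc1)C(=O)CCCOC(=O)c1c(CC)nc(CCC)n1Cc1ccc(-c2ccccc2-c2nn[nH]n2)cc1`, 300 nM in this assay

Of the two numbers, compound 2 has the higher one, and its nearest neighbour is compound 1, whose number lies far enough below it that the gap is beyond the scatter of repeated measurements. The two compounds differ in several places at once, so nothing can be said about which change carries the gap.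

Compound 3 `CCCCN(CCCC)C(=O)CCCOC(=O)c1c(CC)nc(CCC)n1Cc1ccc(-c2ccccc2-c2nn[nH]n2)cc1` has not yet been measured. It differs from compound 2 in one place: propyl in place of phenyl on a saturated chain carbon bound to an amide-type nitrogen. Cut one bond further out, this reads as benzyl to butyl on the amide-type nitrogen. Within the data shown here, no step of this kind appears among the measured pairs, so the expectation rests on the change alone. A modest step in either direction is expected, likely within the scatter, giving an estimated value for compound 3 of 300 nM, with a range from 80 nM to 1200 nM. The estimated step is no change at the digits printed from compound 2 to compound 3 (within the scatter).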

Compound 3, half-maximal inhibitory concentration: 500 nM
Beside the measured number, compound 3's estimate is 1.7-fold (0.22 log units) below it; the measured number falls inside the stated range.
By their numbers in this assay, from the lowest: compound 1; then compounds 2 and 3 (each within the scatter of the next).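

In this assay, exchanging benzyl for butyl on the amide-type nitrogen gives a 1.7-fold higher number from compound 2 to compound 3 (0.22 log units; within the scatter), so the two compounds of this pair cannot be told apart. Among these compounds, this is the first pair here that differs in one place only, and it shows that, in this one case, a phenyl with its aromatic ring can give way to a propyl with no ring without a difference beyond the scatter. Nothing available here gives a reason for this outcome.

As far as these compounds go, a longer chain such as hexyl, or an amine or a carboxylic acid at the end of the butyl chain, remains open at this position. Compound 1, at 3 nM, differs from both in several places, so what carries its gap cannot be read.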